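The source may hold more compounds than are shown below. What is called first, only, known or untested is meant among the compounds shown, and "the series" means these compounds.

Measured so far in a functional assay on MCF7 cells (Homo sapiens) for inhibition, read by MTT assay (a higher number here means a weaker inhibitor, a lower number a stronger inhibitor), are these compounds:
- compound 1 `COc1cc2ncnc(Nc3ccc(NC(=O)c4ccccc4OC)cc3)c2cc1OC` gives > 100000 nM (a limit of the assay)
- compound 2 `COc1cc2ncnc(Nc3ccc(NC(=O)c4ccc(C(C)(C)C)cc4)cc3)c2cc1OC` gives > 100000 nM (a limit of the assay)
- compound 3 `COc1cc2ncnc(Nc3ccc(NC(=O)c4ccc(F)cc4)cc3)c2cc1OC` gives 27000 nM (a true number)

For the measured compounds named here, compound 3 at 27000 nM holds the only true number in the set. The other two results are limits and carry no number (the limit of > 100000 nM in this assay, at which 2 of the 3 values shown sit).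

Compound 4 `COc1cc2ncnc(Nc3ccc(NC(=O)c4cccc(Cl)c4)cc3)c2cc1OC` is unmeasured and differs from compound 3 in one place: 3-chlorophenyl in place of 4-fluorophenyl on a carbonyl carbon. Going by the values given here, no measured compound carries 3-chlorophenyl, so no step reports on it directly.

Among the compounds with values here, the steps that bear on it change the group on that same carbonyl carbon. Each of them starts from a limit and gives a minimum size only. The third step, a step that the two limits leave unreadable from compound 1 to compound 2 (no size can be taken from it), adds nothing.

Read in reverse, an at least 3.7-fold lower number from compound 1 to compound 3 (0.56 log units; beyond the scatter) and an at least 3.7-fold lower number from compound 2 to compound 3 (0.56 log units; beyond the scatter) show both known departures from 4-fluorophenyl ending at a limit, so a move toward a higher number is expected for compound 4. The step expected in this assay is a 1.7-fold higher number from compound 3 to compound 4 (0.22 log units; within the scatter) (a modest rise, with a limit result still possible). For compound 4 the estimated value is 45000 nM (expected range 12000 nM to 100000 nM).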

Compound 4, half-maximal inhibitory concentration: 18000 nM
Compound 4: middle estimate off by 2.5-fold (0.40 log units), on the high side; low and high end bracket the measured number.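

In this assay, 3-chlorophenyl on this carbonyl carbon gives a second true number in the set, and the step to it does not separate it from 4-fluorophenyl: a 1.5-fold lower number from compound 3 to compound 4 (0.18 log units; within the scatter). A readable result at this position is therefore not confined to 4-fluorophenyl, and in these four compounds the two halogen-bearing phenyl groups give true numbers, while 2-methoxyphenyl and 4-(tert-butyl)phenyl do not, with an at least 5.5-fold lower number from compound 2 to compound 4 (0.74 log units; beyond the scatter) and an at least 5.5-fold lower number from compound 1 to compound 4 (0.74 log units; beyond the scatter). Both of these steps are minimum sizes only, since compound 1 and compound 2 carry a limit and not a number: the limit of > 100000 nM in this assay, at which 2 of the 4 values shown sit.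

On these data alone, compound 4 changes both the halogen and the place it occupies relative to compound 3, so the two changes cannot be told apart, and it remains open which of them, if either, matters in this assay. As far as these compounds go, how an unsubstituted phenyl, or a phenyl carrying an amine or a carboxylic acid, would behave on this carbonyl carbon is also open, as is whether any group here can give a number far below those of compound 3 and compound 4.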